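From oxan-4-yl to cyclobutyl: expecting a higher number

This account rests on a few compounds, and the source may have more. Where it says the series, first, only, none or still open, it means among the compounds named here.

Of the compounds shown here, three sharing one core have been measured in a physicochemical assay for solubility, in phosphate buffer, at pH 6.8; a lower number here means a less soluble compound, a higher number a more soluble compound. There, compound 1 `CCn1c(NC2CC2)nc2ccsc2c1=O` gives 430 ug/mL and compound 2 `CCNc1nc2ccsc2c(=O)n1CC` gives 240 ug/mL. These two cannot be told apart, as the data show a 1.8-fold lower number from compound 1 to compound 2 (0.25 log units; within the scatter). Compound 3 `CCn1c(NC2CCOCC2)nc2ccsc2c1=O` gives 37 ug/mL, the lowest of the three numbers. The data show a 12-fold lower number from compound 1 to compound 3 (1.07 log units; beyond the scatter), and also a 6.5-fold lower number from compound 2 to compound 3 (0.81 log units; beyond the scatter).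

The next compound, compound 4 `CCn1c(NC2CCC2)nc2ccsc2c1=O`, has not yet been measured. It carries cyclobutyl in place of oxan-4-yl on a nitrogen on an aromatic ring. Cyclobutyl itself has no measured example here, so the closest evidence comes from compound 1 with cyclopropyl and compound 2 with ethyl. Both of these groups contain carbon only, and neither compound goes against the trend: each stands well above compound 3. The two steps into compound 3 therefore bear most directly on this change, read in reverse. They suggest a rise of modest to large size in this assay, and the step is expected to land short of the larger one. The estimated change is a 4.6-fold higher number from compound 3 to compound 4 (0.66 log units; beyond the scatter). For compound 4 the expected value is 170 ug/mL, with an estimated range from 75 ug/mL to 400 ug/mL.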

Compound 4, solubility: 6.3 ug/mL
The estimate for compound 4 lay 27-fold (1.43 log units) above the measured number; measured number below the stated range.
By their numbers in this assay, from the lowest: compound 4; then compound 3; then compounds 2 and 1 (each within the scatter of the next).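

In this assay the groups made only of carbon no longer all stand above oxan-4-yl on this nitrogen: cyclobutyl in its place gives a 5.9-fold lower number from compound 3 to compound 4 (0.77 log units; beyond the scatter) and leaves compound 4 with the lowest number of the four. The carbon-only groups also differ sharply among themselves, since exchanging the cyclopropyl ring for the cyclobutyl ring brings a 68-fold lower number from compound 1 to compound 4 (1.83 log units; beyond the scatter) while exchanging ethyl for cyclobutyl brings a 38-fold lower number from compound 2 to compound 4 (1.58 log units; beyond the scatter) even though compound 1 and compound 2 lie within the scatter of each other, so a small change in the group at this position can move the number a long way and the presence or absence of a ring oxygen does not sort these compounds. Nothing measured alongside these compounds offers an explanation for the drop.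

The compounds shown leave open whether the low number belongs to cyclobutyl alone or extends to other carbon rings on this nitrogen, such as cyclopentyl or cyclohexyl, the all-carbon counterpart of oxan-4-yl. They also leave open what an amine on the cyclobutyl ring, or a longer chain such as propyl in place of ethyl, would do here.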